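This account rests on a few compounds, and the source may have more. Where it says the series, first, only, none or still open, it means among the compounds named here.

Three compounds have been measured in a physicochemical assay for lipophilicity; a lower number here means a more polar compound, a higher number a more lipophilic compound:
compound 1 `CC1(C)CC(NC(=O)C/C=C/[C@H](NC(=O)OC(C)(C)C)c2ccccc2)CC(C)(C)N1` gives 2.9;
compound 2 `CC(C)C[C@@H](/C=C/C1(C(=O)NC2CC(C)(C)NC(C)(C)C2)CC1)NC(=O)OC(C)(C)C` gives 3.5;
compound 3 `CC1(C)CC(NC(=O)C(/C=C/[C@@H](NC(=O)OC(C)(C)C)c2ccc(F)cc2)(Cc2ccc(F)cc2)Cc2ccc(F)cc2)CC(C)(C)N1` gives 7.9.

Compound 3 stands highest of the three in this assay; compound 2 lies nearest to it and compound 1 furthest, both gaps well beyond the scatter. Compound 4 `CC1(C)CC(NC(=O)C(/C=C/[C@H](NC(=O)OC(C)(C)C)c2ccc(F)cc2)(Cc2ccc(F)cc2)Cc2ccc(F)cc2)CC(C)(C)N1` has not yet been measured. Compared with compound 3, (the two compounds have the same atoms and bonds and differ only in configuration as drawn: 1 of 2 stereo elements differ; a stereocentre at a saturated chain carbon is drawn R in compound 3 and S in compound 4). Going by the values given here, no pair of measured compounds differs only in configuration, so no measured step shows what such a change does here. Since both compounds share every atom and bond, the expected step of no change at the digits printed from compound 3 to compound 4 (within the scatter) lies within the scatter, with no direction favoured. Compound 4 is therefore estimated at 7.9, between 7.5 and 8.3.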

Compound 4, partition coefficient: 7.9
For compound 4 middle estimate and measured number coincide at the digits printed; measured number inside the range.
By their numbers in this assay, from the lowest: compound 1; then compound 2; then compounds 3 and 4 (each within the scatter of the next).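

In this assay, going by these compounds alone, this pair gives the first measured step at a stereocentre, no change at the digits printed from compound 3 to compound 4 (within the scatter). Drawing this saturated chain carbon as S rather than R therefore leaves the reading within the scatter for this pair. The likely reason for so small a step is simple: the fact that compounds 3 and 4 differ only in the configuration as drawn

The compounds shown leave open whether configuration at this carbon would stay as silent in a compound carrying a carboxylic acid in place of a fluorine atom. They also leave open what changing the other stereo element would do.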